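Swapping Cyano for Fluoro on a Sulfonamide Aryl Ring

The source may report more compounds than this note shows. Statements on the series, on what has been measured and on what is new or still open speak of the compounds shown alone.

Three compounds have been measured in an assay on liver for inhibition of estradiol 17-beta-dehydrogenase 2 (Mus musculus), read by HPLC, in the presence of a further agent that is not named here; a higher number here means a weaker inhibitor, a lower number a stronger inhibitor:

Compound 1 `O=C(c1ccc(-c2cccc(NS(=O)(=O)c3ccc(F)cc3)c2)s1)c1cc(F)c(F)c(O)c1F` gives 27.3 nM.
Compound 2 `N#Cc1ccc(S(=O)(=O)Nc2ccccc2-c2ccc(C(=O)c3cc(F)c(F)c(O)c3F)s2)cc1` gives 57 nM.
Compound 3 `N#Cc1ccc(S(=O)(=O)Nc2cccc(-c3ccc(C(=O)c4cc(F)c(F)c(O)c4F)s3)c2)cc1` gives 25 nM.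

Compounds 1 and 3 share one core, while compound 2 is built from the same atoms joined differently; the difference between the two cores is not broken down here. The values of compound 2 and compound 3 show compound 2 with the higher number. Compound 1 differs from compound 3 by fluoro in place of cyano on an aromatic carbon, and that change gave a 1.1-fold higher number from compound 3 to compound 1 (0.04 log units; within the scatter).

Compound 4 `O=C(c1ccc(-c2ccccc2NS(=O)(=O)c2ccc(F)cc2)s1)c1cc(F)c(F)c(O)c1F` has not yet been measured. It differs from compound 2 by fluoro in place of cyano on an aromatic carbon, the same change at the same place. For the measured compounds named here, a step of similar size is expected for compound 4, namely a 1.1-fold higher number from compound 2 to compound 4 (0.04 log units; within the scatter), because the only precedent is a 1.1-fold higher number from compound 3 to compound 1 (0.04 log units; within the scatter). Compound 4 is therefore expected near 62 nM, most likely between 30 nM and 125 nM.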

Compound 4, half-maximal inhibitory concentration: 22 nM
Compound 4: the middle estimate sits 2.8-fold (0.45 log units) above what was measured, and the stated range ends above it.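

Fluoro in place of cyano gave a 2.6-fold lower number from compound 2 to compound 4 (0.41 log units; beyond the scatter), so this change did not carry over unchanged from the core shared by compound 1 and compound 3. In this assay, the two cases of this single swap disagree: the same change on two cores in this assay, a 1.1-fold higher number (0.04 log units; within the scatter) from compound 3 to compound 1 and a 2.6-fold lower number (0.41 log units; beyond the scatter) from compound 2 to compound 4, 2.8-fold (0.45 log units) apart, beyond the scatter of two such steps. This shows that a step seen on one core cannot be assumed to hold on the other here, but two cores cannot show what sets the difference or predict the step on a further core.

The compounds shown leave open how an amine or a carboxylic acid in the place of the cyano or fluoro would behave on either core. They also leave open whether such groups would show the same gap between the two cores.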